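The source may report more compounds than this note shows. Statements on the series, on what has been measured and on what is new or still open speak of the compounds shown alone.

Working notes on the series. Compound 3 `CCCC(C)OC(=O)Nc1cc2nc(C3CCCCC3)[nH]c2cc1N(CC)CC` is compared with compound 1 `CCCCNC(=O)Nc1cc2nc(C3CCCCC3)[nH]c2cc1N(CC)CC` and compound 2 `CCN(CC)c1cc2[nH]c(C3CCCCC3)nc2cc1NC(=O)c1ccc(F)cc1` in an ADME assay on Vero cells (Chlorocebus sabaeus) for cytotoxicity, read by resazurin assay, with a stated time of 3 days; a lower number here means a stronger inhibitor, a higher number a weaker inhibitor. In this assay compound 3 gives only a limit, > 100 ug/mL. Compound 1 also reaches only a limit, > 100 ug/mL. Compound 2 likewise sits at a limit, > 100 ug/mL. Thus (the limit of > 100 ug/mL in this assay, at which 3 of the 3 values shown sit), and the steps a step that the two limits leave unreadable from compound 1 to compound 2, a step that the two limits leave unreadable from compound 1 to compound 3 and a step that the two limits leave unreadable from compound 2 to compound 3 carry no readable size. Compound 4 `CCN(CC)c1cc2[nH]c(C3CCCCC3)nc2cc1NC(=O)c1ccc(Br)cc1` is not yet measured. The change from compound 3 is 4-bromophenyl in place of 1-methylbutoxy on a carbonyl carbon. Compound 2, carrying 4-fluorophenyl on the same carbonyl carbon, stands at its limit. On that basis the expected step is a step that the limit leaves unreadable from compound 3 to compound 4, none beyond the scatter. Compound 4 is expected to give 150 ug/mL, within 100 ug/mL to 300 ug/mL, most probably again as a limit.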

Compound 4, half-maximal inhibitory concentration: > 100 ug/mL
Compound 4 gave a limit, no number; the forecaster's own chance of this, stated with the estimate: 85%; the middle value lies beyond the limit too.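

For the compounds shown here, no step from compound 1, compound 2 or compound 3 to compound 4 can be read in this assay, since every value is a limit: the limit of > 100 ug/mL in this assay, at which 4 of the 4 values shown sit. The compounds shown leave open whether any change on the carbonyl carbon alters the read-out in this assay.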